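Compound 1 and a piperazinyl replacement

The compounds below may be only part of what the source reports. "The series", "measured", "known", "first", "only" and "open" are said of these compounds alone.

- Compound 1 `COc1ccc(/C=N/NC(=O)c2cn(C3CC3)c3cc(N/N=C/c4ccc(OC)c(O)c4)c(F)cc3c2=O)cc1O`: <= 25000 nM (a limit)
- Compound 2 `O=C(N/N=C/c1ccc(F)cc1)c1cn(C2CC2)c2cc(N/N=C/c3ccc(F)cc3)c(F)cc2c1=O`: <= 25000 nM (a limit)

In a functional assay on L1210 cells (Mus musculus) for antiproliferative activity, read by MTT assay (a lower number here means a stronger inhibitor, a higher number a weaker inhibitor), compound 1 gives <= 25000 nM, which is a limit and not a number. Compound 2 shares that standing, so the evidence amounts to the limit of <= 25000 nM in this assay, at which 2 of the 2 values shown sit. Compound 3 `COc1ccc(/C=N/NC(=O)c2cn(C3CC3)c3cc(N4CCNCC4)c(F)cc3c2=O)cc1O`, not yet measured, departs from compound 1 on an aromatic carbon, ortho to a fluoro group: a group of 6 heavy atoms (4 carbon, 2 nitrogen; one six-membered non-aromatic ring with 2 hetero atoms) in place of a group of 12 heavy atoms (8 carbon, 2 nitrogen, 2 oxygen; one six-membered aromatic ring of carbon only), on an aromatic carbon. Among the measured compounds shown here, no measured step shows what such a replacement does in this assay, so any expectation is tentative. A modest move toward weaker inhibition is expected, an at least 1.2-fold higher number from compound 1 to compound 3 (0.07 log units; that floor lies within the scatter). Compound 3 is estimated at 30000 nM, with an expected range from 8000 nM to 100000 nM.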

Compound 3, half-maximal inhibitory concentration: <= 25000 nM
Compound 3 was reported as a limit; the forecaster's own chance of this, stated with the estimate: 35%; at least 1.2-fold (0.07 log units) between middle value and limit.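

Among the compounds shown here, compound 1 and compound 3 both stand only as limits in this assay, so no step between them can be read. The compounds shown leave open what the piperazin-1-yl replacement does to inhibition.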